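The source may report more compounds than this note shows. Statements on the series, on what has been measured and on what is new or still open speak of the compounds shown alone.

Compound 1 `C[C@H]1O[C@]1(C)C(=O)C[C@@H]1[C@@]2(C)[C@@H](O)CCC(C)(C)[C@]2(O)CC[C@@]1(C)O`: > 10000 nM
Compound 2 `C[C@@H]1O[C@@]1(C)C(=O)C[C@@H]1[C@@]2(C)[C@@H](O)CCC(C)(C)[C@]2(O)CC[C@@]1(C)O`: > 10000 nM

Both compounds were tested in an ADME assay on HUVEC cells (Homo sapiens) for cytotoxicity, read by MTT assay, with a stated time of 24 h; a lower number here means a stronger inhibitor, a higher number a weaker inhibitor. Compound 2 gives > 10000 nM, which is a limit of this assay and not a number. Compound 1 gives > 10000 nM, also a limit. The record so far is therefore (the limit of > 10000 nM in this assay, at which 2 of the 2 values shown sit), together with the fact that compounds 1 and 2 differ only in the configuration as drawn.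

Compound 3 `C/C=C(\C)C(=O)C[C@@H]1[C@@]2(C)[C@@H](O)CCC(C)(C)[C@]2(O)CC[C@@]1(C)O`, not yet measured, keeps the shared core and the carbonyl. It differs from compound 2 as follows: 1-methylprop-1-en-1-yl in place of 2,3-dimethyloxiran-2-yl on a carbonyl carbon. In words, 1-methylprop-1-en-1-yl stands in place of 2,3-dimethyloxiran-2-yl on a carbonyl carbon.

Within the data shown here, the only measured step is a step that the two limits leave unreadable from compound 1 to compound 2. It has no readable size and concerns configuration alone, so it gives little guidance on replacing the group. The expectation rests mainly on compound 2 with > 10000 nM, a limit, and no direction of change can be firmly assigned. The expected step is small: a step that the limit leaves unreadable from compound 2 to compound 3. A report of only a limit is the likeliest outcome. For compound 3 the estimated half-maximal inhibitory concentration is 15000 nM, with an expected range of 6000 nM to 50000 nM.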

Compound 3, half-maximal inhibitory concentration: > 10000 nM
Compound 3: no number, only a limit; the forecaster's own chance of this, stated with the estimate: 85%; the middle value does not contradict the limit.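

In this assay compound 3 gives > 10000 nM, a limit and not a number, so neither the step from compound 2 to compound 3 nor that from compound 1 to compound 3 can be read. Compound 1, compound 2 and compound 3 leave open whether replacing 2,3-dimethyloxiran-2-yl with 1-methylprop-1-en-1-yl, or changing the configuration as drawn, alters the half-maximal inhibitory concentration at all.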